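The compounds below may be only part of what the source reports. "The series", "measured", "known", "first", "only" and "open" are said of these compounds alone.

Compound 1 `CN1CCN(c2ccc(Nc3ncc4c(n3)N(C3CCCC3)CC(=O)N4C)cc2)CC1` and compound 2 `CN1C(=O)CN(C2CCCC2)c2nc(Nc3ccc(N4CCCCC4)cc3)ncc21` share one core and differ in a single group. In an ADME assay on HEK293 cells (Homo sapiens) for inhibition, read by MTT assay, with a stated time of 48 h (on this read-out higher numbers stand for weaker inhibition and lower numbers for stronger inhibition), compound 1 gives 12400 nM, while compound 2 gives 25300 nM, a step of a 2.0-fold higher number from compound 1 to compound 2 (0.31 log units; beyond the scatter) made by the change (piperidin-1-yl in place of 4-methylpiperazin-1-yl on an aromatic carbon). Compound 3 `CCN1C(=O)CN(C2CCCC2)c2nc(Nc3ccc(N4CCN(C)CC4)cn3)ncc21` carries a second core; how that core differs from the core of compound 1 is not broken down here. For compound 3 this assay reports only a limit, > 30000 nM, which is the limit of > 30000 nM in this assay, at which 1 of the 3 values shown sits. Compound 4 `CCN1C(=O)CN(C2CCCC2)c2nc(Nc3ccc(N4CCCCC4)cn3)ncc21` arises from compound 3 by the change (piperidin-1-yl in place of 4-methylpiperazin-1-yl on an aromatic carbon). Among the compounds with values here, it is the same kind of change as the one from compound 1 to compound 2, but its surroundings differ: in compound 2 the group sits on a six-membered aromatic ring of carbon only, whereas in compound 4 it sits on a six-membered aromatic ring with 1 nitrogen, two atoms from the ring nitrogen. Since compound 3 already stands at the limit and the earlier step raised the number, the step from compound 3 to compound 4 is expected to be a step that the limit leaves unreadable from compound 3 to compound 4, a weakening, resting on a 2.0-fold higher number from compound 1 to compound 2 (0.31 log units; beyond the scatter). Compound 4 is therefore estimated at 60000 nM in this assay, within 30000 nM to 150000 nM, most likely reported again only as a limit.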

Compound 4, half-maximal inhibitory concentration: > 30000 nM
Compound 4 was reported as a limit; the forecaster's own chance of this, stated with the estimate: 85%; the middle value is on the limit's open side.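

In this assay compound 4 gives > 30000 nM, which is a limit and not a number. Compound 3 is also reported only as a limit, so no step from compound 3 to compound 4 can be read: the limit of > 30000 nM in this assay, at which 2 of the 4 values shown sit.

The compounds shown leave open whether piperidin-1-yl in place of 4-methylpiperazin-1-yl moves the number on the core of compound 3 as it does on the core of compound 1.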